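The compounds below may be only part of what the source reports. "The series", "measured", "known", "first", "only" and "open" are said of these compounds alone.

Compound 1 `CN(C)c1ncnc2c1c(-c1cc3ccccc3o1)cn2[C@@H]1O[C@H](CO)[C@@H](O)[C@H]1O` carries a dimethylamino group on its core and a 1-benzofuran-2-yl group on an aromatic carbon. In a functional assay on HCT-116 cells (Homo sapiens), read by MTT assay, with a stated time of 72 h (a higher number here means a weaker inhibitor, a lower number a stronger inhibitor), compound 1 gives > 20000 nM, which is a limit of the assay rather than a measured number (the limit of > 20000 nM in this assay, at which 1 of the 2 values shown sits). Compound 2 `C#Cc1cn([C@@H]2O[C@H](CO)[C@@H](O)[C@H]2O)c2ncnc(N(C)C)c12` keeps the dimethylamino group but has ethynyl in place of 1-benzofuran-2-yl; in this assay compound 2 gives 290 nM. That change produced an at least 68-fold lower number from compound 1 to compound 2 (1.83 log units; beyond the scatter). Compound 3 `CNc1ncnc2c1c(-c1cc3ccccc3o1)cn2[C@@H]1O[C@H](CO)[C@@H](O)[C@H]1O` differs from compound 1 elsewhere: hydrogen in place of methyl on a nitrogen on an aromatic ring. For the measured compounds named here, no measured step touches the amine, so the only guide is that compound 1 sits at the limit of the assay. Compound 3 is therefore expected to stay near that limit, with a step that the limit leaves unreadable from compound 1 to compound 3, and its expected value in this assay is estimated at 25000 nM, within a range from 8000 nM to 80000 nM.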

Compound 3, half-maximal inhibitory concentration: > 20000 nM
Compound 3 ended at the assay's limit; the forecaster's own chance of this, stated with the estimate: 75%; the middle value does not contradict the limit.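

Compound 1 and compound 3 both sit at a limit of the assay rather than at a measured number, so the step between them cannot be read: the limit of > 20000 nM in this assay, at which 2 of the 3 values shown sit.

The compounds shown leave open whether methylamino in place of dimethylamino changes anything when ethynyl, as in compound 2, replaces 1-benzofuran-2-yl.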